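The source may hold more compounds than are shown below. What is called first, only, known or untested is meant among the compounds shown, and "the series" means these compounds.

Measured compounds:
compound 1 `COc1ccc(NC(=O)NC[C@H]2O[C@H](n3cc(C)c(=O)[nH]c3=O)C[C@@H]2O)cc1`: > 50000 nM
compound 2 `Cc1cn([C@@H]2C[C@H](O)[C@@H](CNC(=S)Nc3ccc(OCc4ccccc4)cc3)O2)c(=O)[nH]c1=O`: > 50000 nM

In an ADME assay on MRC5 cells (Homo sapiens) for cytotoxicity (on this read-out lower numbers stand for higher toxicity in this test and higher numbers for lower toxicity in this test), compound 1 reports only a limit, > 50000 nM. Compound 2 likewise reports only a limit, > 50000 nM. Both measured values therefore sit at the limit of > 50000 nM in this assay, at which 2 of the 2 values shown sit, so nothing sets compound 1 apart on the numbers shown. Compound 3 `Cc1cn([C@@H]2C[C@H](O)[C@@H](CNC(=O)Nc3ccc(OCc4cccc(Cl)c4)cc3)O2)c(=O)[nH]c1=O` differs from compound 1 by 3-chlorophenyl in place of hydrogen on a saturated chain carbon bound to an oxygen on an aromatic ring. Going by the values given here, no measured step covers such a change, so no shift beyond the scatter is expected: the expected step is a number no higher from compound 1 to compound 3 (the limit leaves the size open). Compound 3 is estimated at 50000 nM, with a range from 20000 nM to 100000 nM.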

Compound 3, half-maximal cytotoxic concentration: > 50000 nM
Compound 3 was reported as a limit; the forecaster's own chance of this, stated with the estimate: 70%; the middle value sits exactly at the limit.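

In this assay, compound 1 and compound 3 both report only limits, so no step can be read between them. The compounds shown leave open whether (3-chlorobenzyl)oxy in place of methoxy changes cytotoxicity at all, as every value rests on one limit: the limit of > 50000 nM in this assay, at which 3 of the 3 values shown sit.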